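The source may report more compounds than this note shows. Statements on the series, on what has been measured and on what is new or still open speak of the compounds shown alone.

Of the compounds shown here, three built on one shared core have been measured in a physicochemical assay for solubility, at pH 7; a lower number here means a less soluble compound, a higher number a more soluble compound. Compound 1 `CNC(=O)c1cc(Oc2ccc3nc(Nc4cccc(C(C)(C)C)c4)ccc3c2)ccn1` gives < 1000 nM in this assay, which is a limit of the assay rather than a number. Compound 2 `CNC(=O)c1cc(Oc2ccc3nc(Nc4ccccc4Oc4ccccc4)ncc3c2)ccn1` gives < 1000 nM in this assay, again only a limit. Compound 3 `CNC(=O)c1cc(Oc2ccc3nc(Nc4cccc(Br)c4)ncc3c2)ccn1` likewise reaches only a limit in this assay, with < 1000 nM. Among the measured compounds shown here, compound 3 therefore stands exactly where every value so far stands, namely at the limit of < 1000 nM in this assay, at which 3 of the 3 values shown sit, and nothing measured separates it from the other two.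

Compound 4 `CNC(=O)c1cc(Oc2ccc3nc(Nc4ccc(C(F)(F)F)cc4)ncc3c2)ccn1` has not yet been measured. It differs from compound 3 in one place: 4-(trifluoromethyl)phenyl in place of 3-bromophenyl on a nitrogen on an aromatic ring. For the measured compounds named here, both groups are uncharged carbon rings with no hydrogen-bond donors and no acceptors, and nothing measured so far gives a basis for a step in either direction. The expected step from compound 3 to compound 4 in this assay is a step that the limit leaves unreadable from compound 3 to compound 4, that is, none beyond the scatter. Compound 4 is accordingly estimated to give about 500 nM in this assay, within a range from 100 nM to 2000 nM, and most likely to be reported again only as a limit.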

Compound 4, solubility: < 1000 nM
Compound 4: no number, only a limit (the forecaster's own chance of this, stated with the estimate: 75%); the middle value lies beyond the limit too.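

In this assay, among the compounds shown here, compound 3 and compound 4 both give only a limit of the assay, so no step between compound 3 and compound 4 can be read. The compounds shown leave open the actual value of each one and whether any of them truly differs from another: the limit of < 1000 nM in this assay, at which 4 of the 4 values shown sit.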